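The source may report more compounds than this note shows. Statements on the series, on what has been measured and on what is new or still open speak of the compounds shown alone.

Compound 1 `Cc1ccc(-n2cc(CNC(=O)c3cccc4c3cnn4C(C)C)nn2)c(C)c1` and compound 2 `CC(C)n1ncc2c(C(=O)NCc3cn(-c4ccccc4F)nn3)cccc21` share one core; the step from compound 1 to compound 2 swaps one group on the ring nitrogen. In a functional assay on HepG2 cells (Homo sapiens) for inhibition, read by MTT assay, with a stated time of 72 h (a higher number here means a weaker inhibitor, a lower number a stronger inhibitor), compound 1 gives only a limit, > 40000 nM. Compound 2 likewise gives only a limit in this assay, > 40000 nM. The step that the two limits leave unreadable from compound 1 to compound 2 is therefore unreadable, both values sitting at the limit of > 40000 nM in this assay, at which 2 of the 2 values shown sit. Compound 3 `CC(C)n1ncc2c(C(=O)NCc3cn(Cc4ccc(C#N)cc4)nn3)cccc21` differs from compound 2 by 4-cyanobenzyl in place of 2-fluorophenyl on an aromatic nitrogen. No readable step bears on this change, so no movement beyond the scatter is expected and a limit is again likely; compound 3 is estimated at 50000 nM (range 15000 nM to 200000 nM), a step that the limit leaves unreadable from compound 2 to compound 3 that is expected, not measured.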

Compound 3, half-maximal inhibitory concentration: > 40000 nM
Compound 3 gave a limit, no number (the forecaster's own chance of this, stated with the estimate: 80%); the middle value is on the limit's open side.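

In this assay compound 1, compound 2 and compound 3 all give limits, so no step among them can be read: the limit of > 40000 nM in this assay, at which 3 of the 3 values shown sit.
What the compounds shown leave open is whether any group on this aromatic nitrogen gives a readable value in this assay at all.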